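Cytotoxicity in rat cells: three measured compounds and a fourth

The source may hold more compounds than are shown below. What is called first, only, known or untested is meant among the compounds shown, and "the series" means these compounds.

Compound 1, `COc1cc(NC(C)CCCNC(=O)/C=C/c2ccccc2F)c2ncccc2c1`: 3500 nM
Compound 2, `COc1cc(NC(C)CCCNC(=O)Nc2cc(C(F)(F)F)cc(C(F)(F)F)c2)c2ncccc2c1`: 14900 nM
Compound 3, `COc1cc(NC(C)CCCNC(=O)NNC(=O)/C=C/c2ccc(OC)c(OC)c2)c2ncccc2c1`: 37000 nM

The three compounds were tested in an ADME assay on L6 cells (Rattus norvegicus) for cytotoxicity, read by resazurin assay, with a stated time of 70 h; on this read-out lower numbers stand for stronger inhibition and higher numbers for weaker inhibition. Compound 3 stands at the top of the numbers, with a cytotoxicity reading of 37000 nM. Its nearest neighbour is compound 2, which gives 14900 nM, a gap beyond the scatter; compound 1, with 3500 nM, lies furthest away, also beyond the scatter. Among these three, compound 3 is therefore the least cytotoxic in this assay.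

Compound 4, `COc1cc(NC(C)CCCNC(=O)NNC(=O)Nc2cccc(Cl)c2)c2ncccc2c1`, has not yet been measured. It differs from compound 3 in one place: (3-chlorophenyl)amino in place of 2-(3,4-dimethoxyphenyl)ethenyl on a carbonyl carbon. The shared core and the chain to the carbonyl carbon stay as they are.

Among the measured compounds shown here, no measured pair shows this exact change, so the expectation rests on the spread of the three values. The two ureas and the ester-like amide differ by less than a single order of magnitude overall, and the change from compound 3 to compound 4 removes the ethenyl linker but keeps a single aromatic ring. Compound 4 is expected to land within or just below the scatter of compound 3, a step of a 1.5-fold lower number from compound 3 to compound 4 (0.17 log units; within the scatter). The cytotoxicity of compound 4 is estimated at 25000 nM, with a range from 8000 nM to 80000 nM.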

Compound 4, half-maximal inhibitory concentration: 58600 nM
The estimate for compound 4 lay 2.3-fold (0.37 log units) below the measured number; the range from low to high includes it.
By their numbers in this assay, from the lowest: compound 1; then compound 2; then compounds 3 and 4 (each within the scatter of the next).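

Among the compounds shown here, the three earlier compounds offered no pair differing in one place, so this is the first direct view of a change at this position. In this assay, putting (3-chlorophenyl)amino in place of 2-(3,4-dimethoxyphenyl)ethenyl on a carbonyl carbon gives a 1.6-fold higher number from compound 3 to compound 4 (0.20 log units; within the scatter), so the two compounds cannot be told apart on this read-out, even though the exchange replaces a group of 12 heavy atoms and a double bond outside the aromatic ring with one of 8 heavy atoms and a hydrogen-bond donor. Nothing available explains why the reading holds across this exchange.

The compounds shown carry an aromatic ring in both groups at this position, so they leave open whether the reading would also hold with a carboxylic acid, a primary amine or a simple methyl group on that carbonyl carbon. They also leave open how the reading would respond to a longer chain between the carbonyl carbon and the aromatic ring, or to a fluorine or a methoxy group in place of the chlorine of the (3-chlorophenyl)amino group.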